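Replacing 3,5-dinitrophenyl with (2-chlorophenoxy)methyl

This account rests on a few compounds, and the source may have more. Where it says the series, first, only, none or still open, it means among the compounds named here.

Three measured compounds share one core and differ only on a saturated chain carbon bound to an oxygen next to a carbonyl group. Compound 1 `CCCCCOC(=O)C1=C(C)NC(C)=C(C(=O)OCC)C1c1cccc([N+](=O)[O-])c1` gives 49 nM in a functional assay on HEK293 cells for antagonist activity at Voltage-dependent L-type calcium channel subunit alpha-1C (Oryctolagus cuniculus), read by FLIPR; a higher number here means a weaker inhibitor, a lower number a stronger inhibitor. Going by the values given here, compound 2 `CCOC(=O)C1=C(C)NC(C)=C(C(=O)OCc2ccc([N+](=O)[O-])cc2)C1c1cccc([N+](=O)[O-])c1` gives 130 nM in this assay, and the step of a 2.7-fold higher number from compound 1 to compound 2 (0.42 log units; beyond the scatter) is the only measured change at this place. Compound 3 `COC(=O)C1=C(C)NC(C)=C(C(=O)OCc2cc([N+](=O)[O-])cc([N+](=O)[O-])c2)C1c1cccc([N+](=O)[O-])c1` gives 55 nM in this assay, the second highest of the three numbers, within the scatter of compound 1 and beyond it from compound 2. Compound 4 `COC(=O)C1=C(C)NC(C)=C(C(=O)OCCOc2ccccc2Cl)C1c1cccc([N+](=O)[O-])c1` differs from compound 3 by (2-chlorophenoxy)methyl in place of 3,5-dinitrophenyl on a saturated chain carbon bound to an oxygen next to a carbonyl group. Among the compounds with values here, since the one step at this place was modest, a modest step at most, in either direction or none beyond the scatter, is expected in this assay. Compound 4 is estimated at 60 nM, with a range of 20 nM to 200 nM. This estimate means a step of a 1.1-fold higher number from compound 3 to compound 4 (0.04 log units; within the scatter), which is expected to stay within the scatter.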

Compound 4, half-maximal inhibitory concentration: 19 nM
Estimate against measurement, compound 4: 3.2-fold (0.50 log units) above; measured number outside the range, below it.
By their numbers in this assay, from the lowest: compound 4; then compounds 1 and 3 (each within the scatter of the next); then compound 2.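

Going by these compounds alone, at this place on the shared core, a 2.9-fold lower number from compound 3 to compound 4 (0.46 log units; beyond the scatter) in this assay, so the number can move downward here as well as upward, whereas the one earlier step ran toward a higher number. The entering (2-chlorophenoxy)methyl carries no nitro group, so the two nitro groups of 3,5-dinitrophenyl are not needed to keep the number low in this pair. Nothing shown gives a reason for this step.

Still open, as far as these compounds go, is whether the chlorine or the ether oxygen accounts for the step. From the compounds shown here alone, how a plain phenoxy group or a chain ending in an amine would read at this place also remains open.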